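Chloro for methyl on compound 2

The source may report more compounds than this note shows. Statements on the series, on what has been measured and on what is new or still open speak of the compounds shown alone.

In an ADME assay on the whole organism (Mus musculus, strain CD1) for metabolic stability, at a dose of 2 mg/kg by the intravenous route (a lower number here means that the compound disappears faster, a higher number that the compound lasts longer), compound 1 (`CN1CCC(Oc2ccc(N3C(=S)N(c4cnc(C#N)c(C(F)(F)F)c4)C(=O)C34CCC4)cc2)CC1`) gives 46.4 h and compound 2 (`Cc1cc(N2C(=O)C3(CCC3)N(c3ccc(OC4CCNCC4)nc3)C2=S)cnc1C#N`) gives 3 h as the lower of the two numbers, a gap beyond the usual scatter. Among the measured compounds shown here, no measured pair differs in a single place, so nothing measured so far shows the size of one structural change on its own. Compound 3 (`N#Cc1ncc(N2C(=O)C3(CCC3)N(c3ccc(OC4CCNCC4)nc3)C2=S)cc1Cl`) differs from compound 2 by chloro in place of methyl on an aromatic carbon, which turns 6-cyano-5-methylpyridin-3-yl into 5-chloro-6-cyanopyridin-3-yl. With no measurement of this swap, the expectation stays close to compound 2 at 3 h as the nearest reference. The expected change is a 1.2-fold higher number from compound 2 to compound 3 (0.07 log units; within the scatter) and should stay within the usual scatter, with no firm direction. For compound 3 the estimated half-life is 3.5 h (1.5 h to 8 h).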

Compound 3, half-life: 4.1 h
Beside the measured number, compound 3's estimate is 1.2-fold (0.07 log units) below it; the measured number falls inside the stated range.
By their numbers in this assay, from the lowest: compounds 2 and 3 (each within the scatter of the next); then compound 1.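

Among the compounds shown here, this is the first pair that differs in one place only, so the size of a single change can now be read: putting chloro in place of methyl on the aromatic carbon ortho to a cyano group gives a 1.4-fold higher number from compound 2 to compound 3 (0.14 log units; within the scatter) in this assay. At this position, then, the half-life does not separate methyl from chloro, and the two groups can be exchanged here with no effect that stands out from the scatter. No measured information is available to explain this result.

Still open, on these data alone, is how a different kind of group on this same carbon, such as a methoxy group, an amine or a carboxylic acid, would read in this assay. Also open, as far as these compounds go, is whether the same swap would read alike on another core, as one pair speaks only for this setting.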